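Methoxy in place of methylamino on the terminal carbonyl

The source may report more compounds than this note shows. Statements on the series, on what has been measured and on what is new or still open speak of the compounds shown alone.

Going by the values given here, compound 1 `CNC(=O)c1ccccc1-c1ccc([C@@H](C)Nc2nccc(C)c2NC(=O)CC(F)(F)F)cc1` is one of two compounds measured in an in vitro assay on CHO cells for inhibition of B1 bradykinin receptor (Homo sapiens); on this read-out lower numbers stand for stronger inhibition and higher numbers for weaker inhibition. In this assay compound 1 gives 6 nM, the lowest of the two numbers. The other measured compound, compound 2 `COC(=O)c1ccccc1-c1ccc(CNc2ncccc2NC(=O)C(C)C)cc1`, differs from it in several places at once, and in this assay compound 2 gives 230 nM, a gap beyond the scatter; which of its several differences carries that gap cannot be read from these two numbers alone.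

Compound 3 `COC(=O)c1ccccc1-c1ccc([C@@H](C)Nc2nccc(C)c2NC(=O)CC(F)(F)F)cc1` differs from compound 1 in exactly one place: methoxy in place of methylamino on a carbonyl carbon. Among the compounds with values here, no pair of measured compounds shows this single change on its own, so its size is an open question. An amide hydrogen is lost and an acceptor gained at the end of the molecule. A moderate move toward weaker binding is expected, a 3.3-fold higher number from compound 1 to compound 3 (0.52 log units; beyond the scatter). Compound 3 is therefore estimated at 20 nM, within a range from 6 nM to 70 nM.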

Compound 3, inhibition constant: 1.8 nM
For compound 3 the middle estimate is 11-fold (1.05 log units) above the measured one; the whole stated range lies above it.
By their numbers in this assay, from the lowest: compound 3; then compound 1; then compound 2.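

Methoxy in place of methylamino on this carbonyl carbon gives a 3.3-fold lower number from compound 1 to compound 3 (0.52 log units; beyond the scatter) in this assay, so the change leads to modestly stronger inhibition. In this pair, the amide hydrogen of compound 1 is therefore not needed for strong inhibition, since compound 3 has no hydrogen-bond donor at this place and still gives the lower number. No measurement shown here explains why the methoxy compound gives the lower number.

This single pair cannot separate the loss of the donor from the gain of the acceptor, or show whether the step would hold on a different core. On these data alone, how a carboxylic acid, an ethoxy group or a dimethylamino group on the same carbonyl carbon would compare also remains open.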